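The compounds below may be only part of what the source reports. "The series", "measured", "known", "first", "only" and "open" are said of these compounds alone.

Four compounds built on two closely related cores are compared in a functional assay on MIA PaCa-2 cells (Homo sapiens) for antiproliferative activity, read by sulforhodamine B assay, with a stated time of 48 h; a lower number here means a stronger inhibitor, a higher number a weaker inhibitor. Compound 1, `COc1cc(OC)c2sc(-c3ccc(N/C=C\C(=O)c4ccc(OC)c(O)c4)c(C)c3)nc2c1`, gives 22100 nM in this assay. Compound 2, `COc1cc(OC)c2sc(-c3ccc(N/C=C\C(=O)c4ccc(OC)c([N+](=O)[O-])c4)c(C)c3)nc2c1`, differs from compound 1 by nitro in place of hydroxy on an aromatic carbon. In this assay compound 2 gives 13900 nM, so the step is a 1.6-fold lower number from compound 1 to compound 2 (0.20 log units; within the scatter). Compound 3, `COc1ccc(C(=O)/C=C\Nc2ccc(-c3nc4cc(OC)c(OC)c(OC)c4s3)cc2)cc1O`, carries the other core; the difference between the two cores is not broken down here. In this assay compound 3 gives 32800 nM. The values of compound 3 and compound 1 lie within the usual scatter of each other, while the gap from compound 3 to compound 2 lies beyond it.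

Compound 4, `COc1ccc(C(=O)/C=C\Nc2ccc(-c3nc4cc(OC)c(OC)c(OC)c4s3)cc2)cc1[N+](=O)[O-]`, has not yet been measured in this assay. It differs from compound 3 by nitro in place of hydroxy on an aromatic carbon, the same change as that from compound 1 to compound 2, made at the same place, ortho to a methoxy group and meta to a large group; read one bond further out, it turns a 3-hydroxy-4-methoxyphenyl into a 4-methoxy-3-nitrophenyl. Going by the values given here, the only precedent is modest, because the step from compound 1 to compound 2 reads a 1.6-fold lower number from compound 1 to compound 2 (0.20 log units; within the scatter), and a step of similar size is expected here. The expected step is a 1.6-fold lower number from compound 3 to compound 4 (0.19 log units; within the scatter). Compound 4 is therefore estimated to give 21000 nM in this assay, most likely between 10000 nM and 45000 nM.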

Compound 4, half-maximal inhibitory concentration: 15900 nM
For compound 4 the middle estimate is 1.3-fold (0.12 log units) above the measured one, within the range that was stated.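

In this assay, putting nitro in place of hydroxy on an aromatic carbon, the 3-hydroxy-4-methoxyphenyl becoming a 4-methoxy-3-nitrophenyl, gives a 2.1-fold lower number from compound 3 to compound 4 (0.31 log units; beyond the scatter). Set beside the earlier step on the other core, this step points the same way and cannot be told apart from it in size: the same change on two cores in this assay, a 1.6-fold lower number (0.20 log units; within the scatter) from compound 1 to compound 2 and a 2.1-fold lower number (0.31 log units; beyond the scatter) from compound 3 to compound 4, 1.3-fold (0.11 log units) apart, within the scatter of two such steps This shows that, for these two pairs, the change carried over from the core of compound 1 to the core of compound 3 with no measurable difference, although only the step on the core of compound 3 lies beyond the scatter on its own, and two pairs in a single assay do not establish a rule for the series or show why the number falls.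

The compounds shown leave open whether other groups on the same aromatic carbon, such as an amine, a carboxylic acid or a nitrile, would also behave alike on both cores. They also leave open what each difference between the two cores contributes alone, and whether the step would hold in other cell lines or over another exposure time.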